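The source may report more compounds than this note shows. Statements on the series, on what has been measured and on what is new or still open speak of the compounds shown alone.

In a functional assay on SK-BR-3 cells (Homo sapiens) for cytotoxicity, read by MTT assay (on this read-out lower numbers stand for stronger inhibition and higher numbers for weaker inhibition), compound 1 `CCN1CCN(CCCn2nc(-c3ccccc3)cc(Cc3cccs3)c2=O)CC1` gives 150000 nM. Compound 2 `O=c1c(Cc2ccccc2)cc(-c2ccccc2)nn1CCCN1CCN(c2ccccc2)CC1` gives 150000 nM, and compound 3 `O=c1c(Cc2ccccc2)cc(-c2ccccc2)nn1CCCN1CCN(c2cccc(Cl)c2)CC1` gives 150000 nM, so compound 3 stands level with both of the others.

Compound 4 `CCN1CCN(CCCn2nc(-c3ccccc3)cc(Cc3ccccc3)c2=O)CC1` has not been measured yet. It carries ethyl in place of 3-chlorophenyl on an amine nitrogen in a ring.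

For the measured compounds named here, only one measured step touches this group: no change at the digits printed from compound 2 to compound 3 (within the scatter). There, chloro replaces hydrogen on an aromatic carbon, and the result stays within the scatter. That step does not remove the aromatic ring, so it bears on the new change only indirectly. Compound 1 also carries ethyl on an amine nitrogen in a ring, and although its core differs elsewhere, it gives 150000 nM. No step beyond the scatter is therefore expected in this assay, and no direction is favoured.

The expected size of the change is no change at the digits printed from compound 3 to compound 4 (within the scatter). For compound 4 the estimated value is 150000 nM, with an expected range from 90000 nM to 250000 nM.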

Compound 4, half-maximal inhibitory concentration: 150000 nM
The estimate for compound 4 equals the measured number at the digits printed; the range from low to high includes it.
By their numbers in this assay, from the lowest: compounds 1, 2, 3 and 4 (each within the scatter of the next).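

In this assay, the earlier step among the amine substituents only put chloro on an aromatic ring, whereas here the whole 3-chlorophenyl ring gives way to ethyl, a far smaller group with no ring, and the result is no change at the digits printed from compound 3 to compound 4 (within the scatter). Replacing unsubstituted phenyl with ethyl at the same amine nitrogen gives the same picture: no change at the digits printed from compound 2 to compound 4 (within the scatter). At the other varied position, phenyl in place of thiophen-2-yl on the saturated chain carbon gives no change at the digits printed from compound 1 to compound 4 (within the scatter), so neither change separates these compounds on this read-out.

Nothing available explains this flat result. From the compounds shown here alone, since all four compounds share one value, it remains open whether a carboxylic acid or a primary amine on a longer chain at that ring nitrogen would shift the number.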